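The compounds below may be only part of what the source reports. "The series", "measured", "known", "first", "only" and "open" are said of these compounds alone.

Compound 1 `CC(=O)c1ccc(NC(=O)CN(C(=O)c2ccccc2)S(=O)(=O)c2ccc(C)cc2)cc1` gives 18.2% in a functional assay for inhibition, read by spectrophotometry, with a stated time of 20 min, tested at 3 mg/mL; a higher number here means a stronger effect of the compound at the concentration tested, a lower number a weaker effect. Compound 2 `CC(=O)c1ccc(NC(=O)CN(C(=O)c2ccccc2)S(=O)(=O)c2ccc([N+](=O)[O-])cc2)cc1` gives 20.6%. Compound 3 `CC(=O)c1ccc(NC(=O)C(CC(C)C)N(C(=O)c2ccccc2)S(=O)(=O)c2ccc([N+](=O)[O-])cc2)cc1` gives 62.3%.

Among the compounds with values here, on these numbers compound 2 sits in the middle: its nearest neighbour is compound 1, with a step of a number 2.4 percentage points higher from compound 1 to compound 2 (within the scatter), and the only distant one is compound 3, reached by a number 41.7 percentage points higher from compound 2 to compound 3 (beyond the scatter), a change on the chain carbon rather than on the aromatic ring.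

Compound 4 `CC(=O)c1ccc(NC(=O)CN(C(=O)c2ccccc2)S(=O)(=O)c2ccccc2)cc1` differs from compound 2 in one place: hydrogen in place of nitro on an aromatic carbon. Within the data shown here, the measured step that bears on this place is the one from compound 1 to compound 2, where methyl was exchanged for nitro on that same aromatic carbon and the result was a number 2.4 percentage points higher from compound 1 to compound 2 (within the scatter), within the scatter. Two different groups at this position gave much the same read-out, so taking the group away altogether is expected to change little. The step from compound 2 to compound 4 is therefore expected to be a number 1.6 percentage points lower from compound 2 to compound 4 (within the scatter), none beyond the scatter. Compound 4 is estimated to give 19%, in a range from 8% to 32%.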

Compound 4, a percentage reported as inhibition, at one concentration (the size of the read-out at that concentration, not a potency): 40.7%
For compound 4 the middle estimate is 21.7 percentage points below the measured one, and the stated range ends below it.
By their numbers in this assay, from the lowest: compounds 1 and 2 (each within the scatter of the next); then compound 4; then compound 3.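

In this assay, the group on this aromatic carbon does matter: hydrogen in place of nitro gives a number 20.1 percentage points higher from compound 2 to compound 4 (beyond the scatter), and hydrogen in place of methyl gives a number 22.5 percentage points higher from compound 1 to compound 4 (beyond the scatter). Methyl and nitro lie within the scatter of each other, but that agreement did not mean the position was indifferent, since the compound with plain phenyl stands apart from both. The data shown offer no explanation for why these two quite different groups give similar numbers, both lower than with hydrogen.

Going by these compounds, whether every group on this carbon goes with a lower number, or only these two, stays open; an amine, a methoxy group or a chlorine atom would test this. Also open, on these data alone, is whether phenyl in place of 4-nitrophenyl would act the same way in compound 3, which carries the isobutyl on the chain carbon.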